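From pyridin-3-yl to pyridin-4-yl on the shared core

The source may hold more compounds than are shown below. What is called first, only, known or untested is meant among the compounds shown, and "the series" means these compounds.

Measured so far in a physicochemical assay for solubility, read by HPLC, using the shake flask method; on this read-out higher numbers stand for higher solubility and lower numbers for lower solubility:
- compound 1 `COC(=O)c1cccc(-c2cnc3[nH]cc(-c4cncnc4)c3c2)c1` gives 28600 nM 
- compound 2 `COC(=O)c1cccc(-c2cnc3[nH]cc(-c4cccnc4)c3c2)c1` gives 4300 nM 

Compound 2 holds the lower of the two numbers. Compound 3 `COC(=O)c1cccc(-c2cnc3[nH]cc(-c4ccncc4)c3c2)c1` is still unmeasured, and the change to it is pyridin-4-yl in place of pyridin-3-yl on an aromatic carbon. Going by the values given here, only one measured step bears on this, the modest 6.7-fold lower number from compound 1 to compound 2 (0.82 log units; beyond the scatter), and it exchanged a different ring at the same place. The new change keeps the counted atoms unaltered, so no step beyond the scatter is expected in this assay. The estimated change is a 1.2-fold lower number from compound 2 to compound 3 (0.09 log units; within the scatter), though the data support no firm direction. Compound 3 is expected to read 3500 nM, with an estimated range from 1200 nM to 10000 nM.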

Compound 3, solubility: 34000 nM
Compound 3: middle estimate off by 9.7-fold (0.99 log units), on the low side, outside the stated range (above it).
By their numbers in this assay, from the lowest: compound 2; then compounds 1 and 3 (each within the scatter of the next).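

In this assay, with the counted atoms unchanged, pyridin-4-yl in place of pyridin-3-yl on this aromatic carbon gives a 7.9-fold higher number from compound 2 to compound 3 (0.90 log units; beyond the scatter), so how the same ring is joined is enough to shift the number beyond the scatter. Pyridin-4-yl in place of pyrimidin-5-yl gives a 1.2-fold higher number from compound 1 to compound 3 (0.08 log units; within the scatter), which leaves compound 2 alone apart from the other two. Nothing at hand accounts for the gap between the pyridin-3-yl and pyridin-4-yl compounds.

Still open, as far as these compounds go, is how an amine on the pyridin-4-yl group would read here, and whether a carboxylic acid in place of the methyl ester would keep this order.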